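Lengthening the Ring Nitrogen Substituent in a Sulfonate Series

The compounds below may be only part of what the source reports. "The series", "measured", "known", "first", "only" and "open" are said of these compounds alone.

Compound 1 `CN1CCN(c2ccc(S(=O)(=O)Oc3cccc(F)c3)cc2)C1=O`: in a functional assay on HT-29 cells (Homo sapiens) for antiproliferative activity, read by sulforhodamine B assay, with a stated time of 48 h (on this read-out lower numbers stand for stronger inhibition and higher numbers for weaker inhibition), compound 1 reaches only a limit, > 100000 nM.
Compound 2 `CN1CCN(c2ccc(S(=O)(=O)Oc3cccc([N+](=O)[O-])c3)cc2)C1=O`: in this assay compound 2 gives 26000 nM.

Compound 1 thus sits at the limit of > 100000 nM in this assay, at which 1 of the 2 values shown sits. For the measured compounds named here, the only measured step, an at least 3.8-fold lower number from compound 1 to compound 2 (0.58 log units; beyond the scatter), concerns the aromatic substituent, not the ring nitrogen. Compound 3 `CCCN1CCN(c2ccc(S(=O)(=O)Oc3cccc(F)c3)cc2)C1=O` differs from compound 1 by ethyl in place of hydrogen on a saturated chain carbon bound to an amide-type nitrogen in a ring. Going by the values given here, no measured step bears on this change, so no shift beyond the scatter is expected in this assay. Compound 3 is therefore expected to remain near the limit, at an estimated 120000 nM, between 30000 nM and 400000 nM. That estimate means an expected step that the limit leaves unreadable from compound 1 to compound 3.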

Compound 3, half-maximal inhibitory concentration: 18000 nM
For compound 3 the middle estimate is 6.7-fold (0.82 log units) above the measured one; measured number outside the range, below it.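

In this assay, replacing methyl with propyl on the ring nitrogen gives an at least 5.5-fold lower number from compound 1 to compound 3 (0.74 log units; beyond the scatter). This shows that the ring nitrogen substituent, and not only the aromatic substituent, can shift the read-out in this series. Compound 1 stands at a limit, so the step gives only a bound on the size of the change: the limit of > 100000 nM in this assay, at which 1 of the 3 values shown sits.

On these data alone, what a butyl chain or a chain carrying an amine would do at this position remains open. So does whether propyl and nitro together would give a further shift.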